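This account rests on a few compounds, and the source may have more. Where it says the series, first, only, none or still open, it means among the compounds named here.

The measured compounds:

Compound 1, `CCCS(=O)(=O)Nc1cccc2c1CCC2c1ncc[nH]1` — in a functional assay on CHO cells for agonist activity at Alpha-1D adrenergic receptor (Homo sapiens), read by FLIPR and calcium flux (on this read-out higher numbers stand for an effect only at larger amounts of compound and lower numbers for an effect already at smaller amounts), compound 1 gives > 10000 nM, a limit of the assay rather than a number.
Compound 2, `CCS(=O)(=O)Nc1cccc(Cc2c[nH]cn2)c1` — in this assay compound 2 gives > 10000 nM, again a limit.
Compound 3, `CS(=O)(=O)Nc1cccc2c1CCCC2c1ncc[nH]1` — in this assay compound 3 gives > 10000 nM; > 10000 nM; > 10000 nM (3 entries), each of the three entries a limit.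

Compound 1 therefore stands nowhere in particular on the numbers shown: its own result is only a limit, and the other two compounds offer nothing better, since the limit of > 10000 nM in this assay, at which 2 of the 3 values shown sit, and the third compound adds only further limits. Among the compounds with values here, no step between measured compounds exists here, so nothing measured tells how a change at this position moves the read-out.

The unmeasured compound 4, `CNC(=O)c1cccc2c1CCC2c1ncc[nH]1`, keeps the core of compound 1 and differs from it in one place: methylcarbamoyl in place of (propylsulfonyl)amino on an aromatic carbon. Whether that exchange lifts the series out of the limit range cannot be read from the three compounds shown, all of which sit at the limit. The expectation is therefore a step from compound 1 to compound 4 of an at least 1.2-fold lower number from compound 1 to compound 4 (0.09 log units; that floor lies within the scatter), that is, none beyond the scatter in this assay, with a fair chance that the assay again reports only a limit. On that basis compound 4 is estimated at 8000 nM, within a range from 1500 nM to 40000 nM.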

Compound 4, half-maximal effective concentration: > 10000 nM
Compound 4: only a limit was reported; the forecaster's own chance of this, stated with the estimate: 55%; middle value at least 1.2-fold (0.09 log units) away from the limit.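

In this assay compound 4 gives > 10000 nM, a limit of the assay and not a number. Within the data shown here, compound 1 likewise gives only a limit, and no step from compound 1 to compound 4 can be read. The compounds shown leave open what actual number, if any, such structures would reach in this assay.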